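Methyl ester of an acid at the aryl position

The source may report more compounds than this note shows. Statements on the series, on what has been measured and on what is new or still open speak of the compounds shown alone.

Compound 2 `Cc1c(Cc2ccc(C(=O)O)cc2S(=O)(=O)c2ccccc2)c2c(n1CC(=O)O)CCNC2=O` carries a carboxy group on the aromatic ring and, in a functional assay on CHO.K1 cells for antagonist activity at prostaglandin D2 receptor 2 (Homo sapiens), read by GTPgammaS binding, with a stated time of 1 h (a higher number here means a weaker inhibitor, a lower number a stronger inhibitor), compound 2 gives 19 nM. Among the two numbers measured so far it has the higher one, yet its nearest neighbour, compound 1 `Cc1c(Cc2ccc(C(F)(F)F)cc2S(=O)(=O)c2ccccc2)c2c(n1CC(=O)O)CCNC2=O`, differs from it only within the scatter: in this assay compound 1 gives 13 nM, and the change a 1.5-fold higher number from compound 1 to compound 2 (0.16 log units; within the scatter), carboxy in place of trifluoromethyl on an aromatic carbon, is too small to count as a real shift.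

Compound 3 `COC(=O)c1ccc(Cc2c3c(n(CC(=O)O)c2C)CCNC3=O)c(S(=O)(=O)c2ccccc2)c1` is the methyl ester of compound 2: the change is methyl in place of hydrogen on an oxygen next to a carbonyl group. No measured step touches this oxygen, so nothing shown here bears on the difference directly. Among the measured compounds shown here, the one step that exists, from compound 1 to compound 2, showed that a swap at this part of the ring hardly moved the number, which gives no reason to expect a large step in either direction for compound 3, though the direction remains open.

Compound 3 is therefore expected to give about 30 nM in this assay, within 8 nM to 120 nM, corresponding to an estimated step of a 1.6-fold higher number from compound 2 to compound 3 (0.20 log units; within the scatter).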

Compound 3, half-maximal inhibitory concentration: 11 nM
Compound 3: middle estimate off by 2.7-fold (0.44 log units), on the high side, within the range that was stated.
By their numbers in this assay, from the lowest: compounds 3, 1 and 2 (each within the scatter of the next).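

In this assay, the hydrogen on this oxygen can give way to methyl without a step beyond the scatter: a 1.7-fold lower number from compound 2 to compound 3 (0.24 log units; within the scatter). Among the compounds shown here, the methoxycarbonyl group likewise cannot be told apart from trifluoromethyl on this aromatic carbon, with a 1.2-fold lower number from compound 1 to compound 3 (0.07 log units; within the scatter), so carboxy, methoxycarbonyl and trifluoromethyl now all read alike here, where the earlier compounds offered only the first and last of these. Nothing available explains why these three groups read alike, and no supporting measurement bears on the result.

Going by these compounds, it remains open whether a longer ester such as the ethyl or benzyl ester, a primary amide, an aminomethyl group or a plain hydrogen on this aromatic carbon would also stay within the scatter of these three compounds. All three also share the phenylsulfonyl group and the acetic acid chain on the core, so the compounds shown do not say whether the same agreement among carboxy, methoxycarbonyl and trifluoromethyl would hold with, for example, a methylsulfonyl group in place of the phenylsulfonyl group.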